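Replacing 4-methylphenyl with pyridin-4-yl in the series

The source may report more compounds than this note shows. Statements on the series, on what has been measured and on what is new or still open speak of the compounds shown alone.

- compound 1 `Cc1ccc(C2(c3ccc(O)cc3)C(=O)Nc3c2ccc(F)c3F)cc1` gives 0.8 nM as a number
- compound 2 `CCCCCOc1ccc(C2(c3ccc(O)cc3)C(=O)Nc3c2ccc(F)c3F)cc1` gives > 1000 nM as a limit

Going by the values given here, in a functional assay on PC-3 cells (Homo sapiens) for cytotoxicity, read by WST assay, with a stated time of 72 h (a higher number here means a weaker inhibitor, a lower number a stronger inhibitor), compound 1 gives 0.8 nM as the only true number so far. Compound 2 stands at the limit of > 1000 nM in this assay, at which 1 of the 2 values shown sits, and so offers no number.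

Compound 3 `O=C1Nc2c(ccc(F)c2F)C1(c1ccncc1)c1ccc(O)cc1` differs from compound 1 by pyridin-4-yl in place of 4-methylphenyl on a saturated ring carbon. Among the compounds with values here, the one measured step of an at least 1200-fold higher number from compound 1 to compound 2 (3.09 log units; beyond the scatter) is large, lies beyond the scatter and alters that same 4-methylphenyl group, so it is the only guide. In this assay a higher number is expected, though a smaller move than that step. The estimated move is a 38-fold higher number from compound 1 to compound 3 (1.57 log units; beyond the scatter) in this reading. For compound 3 the estimate is 30 nM (expected range 3 nM to 300 nM) for the coming measurement.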

Compound 3, half-maximal inhibitory concentration: 110 nM
The estimate for compound 3 lay 3.7-fold (0.56 log units) below the measured number; measured number inside the range.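

In this assay, pyridin-4-yl in place of 4-methylphenyl on the saturated ring carbon gives a 140-fold higher number from compound 1 to compound 3 (2.14 log units; beyond the scatter), so exchanging the ring itself, without any longer chain, already moves the number far. Compound 2 remains a limit and not a number, so its step cannot be sized against this one: the limit of > 1000 nM in this assay, at which 1 of the 3 values shown sits.

As far as these compounds go, whether the change follows the ring nitrogen or the lost methyl stays open. Unsubstituted phenyl and pyridin-3-yl at this carbon would separate the two, and a 4-aminophenyl group would test a different ring substituent.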